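Extending the hydroxymethyl group of compound 2 toward compound 3

A few compounds are considered here, and "the series" means these few. Any claim that something is new, unique, unknown or untested is made for them only; others in the source may bear on it.

Compound 1 `OCc1cc2cc(/C(=N\O)Nc3cccc(F)c3)ccc2o1` carries a fluoro group on its aniline ring; in an assay on tissue (HeLa cells) for inhibition of Indoleamine 2,3-dioxygenase 1 (Homo sapiens), read by spectrophotometry (on this read-out higher numbers stand for weaker inhibition and lower numbers for stronger inhibition), compound 1 gives 2400 nM. Compound 2 `OCc1cc2cc(/C(=N\O)Nc3cccc(Br)c3)ccc2o1` carries a bromo group in the same place, and in this assay compound 2 gives 1200 nM. Within the data shown here, the only measured step, a 2.0-fold lower number from compound 1 to compound 2 (0.30 log units; within the scatter), concerns the halogen on the aromatic carbon. Compound 2 thus holds the lowest of the two numbers, though its gap to compound 1 stays within the scatter.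

Compound 3 `O/N=C(/Nc1cccc(Br)c1)c1ccc2oc(COCC3CC3)cc2c1` keeps the bromo group of compound 2 and differs from it elsewhere: cyclopropylmethyl in place of hydrogen on an oxygen on a saturated carbon. Among the measured compounds shown here, no measured step touches this oxygen, so nothing among the two compounds bears directly on the change; the halogen step is the only guide to how far numbers in this assay move, and it was small. For compound 3 the step is therefore expected to be a 1.2-fold lower number from compound 2 to compound 3 (0.08 log units; within the scatter), with neither direction favoured beyond the scatter. Compound 3 is estimated at 1000 nM in this assay, within a range from 300 nM to 3500 nM.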

Compound 3, half-maximal inhibitory concentration: 3200 nM
Compound 3: middle estimate off by 3.2-fold (0.51 log units), on the low side; measured number inside the range.
By their numbers in this assay, from the lowest: compounds 2, 1 and 3 (each within the scatter of the next, the first and the last beyond it).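

Among these compounds, replacing the hydrogen of the hydroxy group with cyclopropylmethyl gives the only step printed as beyond the scatter: in this assay there is a 2.7-fold higher number from compound 2 to compound 3 (0.43 log units; beyond the scatter), a modest move toward weaker inhibition. The halogen on the aniline ring had not shown this, as a 2.0-fold lower number from compound 1 to compound 2 (0.30 log units; within the scatter), so this oxygen is the one place here where a change moves the number by more than repeat measurements would. The loss is limited, however: compound 3 still gives a measurable number with the whole cyclopropylmethyl group in place, so this position tolerates a larger substituent without inhibition disappearing in this assay. Nothing in the data gives a reason for the rise.

The compounds shown leave open whether the step comes from losing the hydroxy hydrogen or from the cyclopropylmethyl group itself, a question that a simple methoxy or a straight propyl ether at the same oxygen would address. They also leave open how an amine or a carboxylic acid in place of the hydroxy group would read, and whether the same change would give a similar step with fluoro in place of bromo on the aniline ring.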